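Removing an N-Methyl Group from a Weak Sulfonamide Series

A few compounds are considered here, and "the series" means these few. Any claim that something is new, unique, unknown or untested is made for them only; others in the source may bear on it.

Of the compounds shown here, three sharing one sulfonamide core have been measured in a functional assay on ASPC1 cells (Homo sapiens) for inhibition, read by MTT assay, with a stated time of 72 h; on this read-out higher numbers stand for weaker inhibition of growth and lower numbers for stronger inhibition of growth. Compound 1 `O=S(=O)(NCCCNCc1ccccc1Cl)c1cc(C(F)(F)F)cc(C(F)(F)F)c1` gives 13000 nM. Compound 2 `COc1ccc(CNCCCNS(=O)(=O)c2cc(C(F)(F)F)cc(C(F)(F)F)c2)cc1OC` gives 6400 nM. Compound 3 `CN(CCCNS(=O)(=O)c1cc(C(F)(F)F)cc(C(F)(F)F)c1)Cc1ccccc1` gives 51000 nM, the highest number of the three, so on this read-out compound 3 is the weakest growth inhibitor so far, with compound 1 nearest to it and compound 2 furthest away.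

The compound not yet measured is compound 4 `O=S(=O)(NCCCNCc1ccccc1)c1cc(C(F)(F)F)cc(C(F)(F)F)c1`. The change from compound 3 to compound 4 is hydrogen in place of methyl on an amine nitrogen, so the amine becomes a benzylamino group.

Within the data shown here, one measured step touches this position. Going a 3.9-fold higher number from compound 1 to compound 3 (0.59 log units; beyond the scatter), two things changed at once: the chlorine left the phenyl ring and a methyl arrived on the amine nitrogen. Compound 4 carries neither. The other step, a 2.0-fold lower number from compound 1 to compound 2 (0.31 log units; beyond the scatter), concerns only the phenyl ring and says little here. Because a 3.9-fold higher number from compound 1 to compound 3 (0.59 log units; beyond the scatter) worsened the number, undoing the methyl part of that change is expected to lower the number again, placing compound 4 somewhere between compound 3 and compound 1.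

For compound 4 the expected step is a 2.3-fold lower number from compound 3 to compound 4 (0.37 log units; beyond the scatter). Compound 4 is therefore estimated at 22000 nM, with a likely range from 9000 nM to 55000 nM.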

Compound 4, concentration for 50% growth inhibition: 13000 nM
The estimate for compound 4 lay 1.7-fold (0.23 log units) above the measured number; the measured number falls inside the stated range.
By their numbers in this assay, from the lowest: compound 2; then compounds 1 and 4 (each within the scatter of the next); then compound 3.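

In this assay, among these compounds, the methyl on the amine nitrogen can now be read on its own, since hydrogen in its place is the only difference in the step (a 3.9-fold lower number from compound 3 to compound 4 (0.59 log units; beyond the scatter)), whereas the earlier step into compound 3 also changed the phenyl ring. Hydrogen in place of chloro on an aromatic carbon leaves the number where it was (no change at the digits printed from compound 1 to compound 4 (within the scatter)), so the earlier rise into compound 3 tracks the methyl and not the loss of chlorine, while phenyl in place of 3,4-dimethoxyphenyl gives a modest rise (a 2.0-fold higher number from compound 2 to compound 4 (0.31 log units; beyond the scatter)), so among these rings only the dimethoxy pattern moves the number beyond the scatter. Nothing shown here explains why the methyl on this nitrogen goes with weaker inhibition of growth.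

As far as these compounds go, this methyl effect rests on one pair with an unsubstituted phenyl ring, so whether it holds with 3,4-dimethoxyphenyl or 2-chlorophenyl remains open. Also open, from the compounds shown here alone, is how an ethyl group on the same nitrogen, or a longer chain joining the amine to the sulfonamide nitrogen, would compare.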